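The compounds below may be only part of what the source reports. "The series", "measured", "known", "first", "only" and "open" are said of these compounds alone.

Compound 1 `CN(C)CCN1CCN(c2nc(-c3ccccn3)nc3c2CN(Cc2ccccc2)CC3)CC1`: 218000 nM
Compound 2 `CN(C)CCN1CCN(c2nc(-c3cccnc3)nc3c2CN(Cc2ccccc2)CC3)CC1`: 247000 nM
Compound 3 `CN1CCN(CCCNc2nc(-c3ccncc3)nc3c2CN(Cc2ccccc2)CC3)CC1`: 250000 nM

In a physicochemical assay for solubility, read by HPLC, with a stated time of 24 h, at pH 7.4, tested at 250 uM (a higher number here means a more soluble compound, a lower number a less soluble compound), compound 3 gives 250000 nM and so sits level with compound 1 and compound 2, all three within the scatter of one another. Compound 4 `CN(C)CCN1CCN(c2nc(-c3ccncc3)nc3c2CN(Cc2ccccc2)CC3)CC1` keeps the pyridin-4-yl group of compound 3 but changes the side chain: 4-(2-(dimethylamino)ethyl)piperazin-1-yl in place of (3-(4-methylpiperazin-1-yl)propyl)amino on an aromatic carbon. The incoming group already occurs in compound 1 and compound 2. For the measured compounds named here, the one measured step is a 1.1-fold higher number from compound 1 to compound 2 (0.05 log units; within the scatter) and it concerns the pyridine, not the side chain. Compound 1 gives 218000 nM and compound 2 gives 247000 nM with that side chain, so no shift beyond the scatter is expected. The expected step is a 1.1-fold lower number from compound 3 to compound 4 (0.03 log units; within the scatter) in this assay and has no clear direction. Compound 4 is estimated at 235000 nM with an expected range of 170000 nM to 260000 nM in this measurement.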

Compound 4, solubility: 250000 nM
For compound 4 the middle estimate is 1.1-fold (0.03 log units) below the measured one; the range from low to high includes it.
By their numbers in this assay, from the lowest: compounds 1, 2, 3 and 4 (each within the scatter of the next).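

Exchanging (3-(4-methylpiperazin-1-yl)propyl)amino for 4-(2-(dimethylamino)ethyl)piperazin-1-yl at this aromatic carbon gives no change at the digits printed from compound 3 to compound 4 (within the scatter) in this assay, even though the two groups differ in their hydrogen-bond donor count. With the side chain held fixed, pyridin-4-yl also stays within the scatter of the other two pyridines: a 1.0-fold higher number from compound 2 to compound 4 (0.01 log units; within the scatter) and a 1.1-fold higher number from compound 1 to compound 4 (0.06 log units; within the scatter). Nothing measured here gives a reason for this.

Compound 4 at 250000 nM matches the tested concentration, so any solubility beyond that would not show. Going by these compounds, whether a carboxylic acid or a plain methyl group at this carbon would read differently remains open.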